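Carboxy in place of nitro in a growth-inhibition series

This account rests on a few compounds, and the source may have more. Where it says the series, first, only, none or still open, it means among the compounds named here.

Among the compounds with values here, in a functional assay on HepG2 cells (Homo sapiens) for cytotoxicity, read by sulforhodamine B assay, with a stated time of 48 h (a higher number here means a weaker inhibitor of growth, a lower number a stronger inhibitor of growth), compound 1 (`Cc1nn(-c2ccccc2)c(Oc2ccc(-c3nc4cc([N+](=O)[O-])ccc4[nH]3)cc2)c1/C=N/NC(N)=S`) gives 22500 nM, the only number available. For compound 2 (`CC(=O)N/N=C/c1c(C)nn(-c2ccccc2)c1Oc1ccc(-c2nc3cc([N+](=O)[O-])ccc3[nH]2)cc1`) the entry reads "not determined" (no result reported), so it offers no comparison. Compound 3 (`Cc1nn(-c2ccccc2)c(Oc2ccc(-c3nc4cc(C(=O)O)ccc4[nH]3)cc2)c1/C=N/NC(N)=S`) carries carboxy in place of nitro on an aromatic carbon of the core of compound 1 (carboxy in place of nitro on an aromatic carbon). Within the data shown here, no measured pair shows what this change does, so any expectation is tentative: somewhat weaker growth inhibition, slightly beyond the scatter, in this assay. The expected step is a 2.0-fold higher number from compound 1 to compound 3 (0.30 log units; within the scatter). For compound 3 the estimated value is 45000 nM, with an expected range of 15000 nM to 120000 nM.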

Compound 3, concentration for 50% growth inhibition: 46000 nM
For compound 3 the middle estimate is 1.0-fold (0.01 log units) below the measured one; low and high end bracket the measured number.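

In this assay, within the data shown here, carboxy in place of nitro on this aromatic carbon of the shared core gives a 2.0-fold higher number from compound 1 to compound 3 (0.31 log units; beyond the scatter) and so provides the first measured reading of this change. Growth inhibition at this position is modestly weaker with carboxy, yet it still gives a number. Nothing at hand bears on why the step has this size.

From the compounds shown here alone, how an amine or a methyl ester would read on the same carbon remains open. So does whether this step would hold with an acetyl hydrazone side chain in place of the one in compound 1.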